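Removing One Methoxy Group from Compound 1

The source may report more compounds than this note shows. Statements on the series, on what has been measured and on what is new or still open speak of the compounds shown alone.

Of the compounds shown here, two have been measured in an assay for inhibition of Polyunsaturated fatty acid 5-lipoxygenase (Homo sapiens), read by spectrophotometry, tested at 20 uM; on this read-out lower numbers stand for less inhibition and higher numbers for more inhibition at the one concentration tested (going by the name of the read-out). Compound 1 `COc1ccc(/C=C/C=C/C(=O)N2CCCCC2)c(OC)c1OC` carries three methoxy groups, and in this assay compound 1 gives 36%. Compound 2 `O=C(/C=C/C=C/c1ccc(O)c(O)c1)N1CCCCC1`, which instead bears two hydroxyl groups, gives 82.8% in this assay. Compound 1 therefore stands lowest of the two numbers, with compound 2 the nearest and higher by a margin beyond the usual scatter. Among the compounds with values here, no pair of measured compounds differs in only one place, so no single structural change has yet been tied to a shift in the read-out.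

Compound 3 `COc1ccc(/C=C/C=C/C(=O)N2CCCCC2)cc1OC` has not been measured. It differs from compound 1 by one change: hydrogen in place of methoxy on an aromatic carbon. Within the data shown here, nothing among the measured compounds shows what the loss of a single methoxy group does here, so the step expected is no change at the digits printed from compound 1 to compound 3 (within the scatter), which amounts to no change beyond the scatter in either direction. Compound 3 is thus estimated at 36% in this assay, within a range from 16% to 56%.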

Compound 3, a percentage reported as inhibition, at one concentration (the size of the read-out at that concentration, not a potency): 51.9%
Compound 3: middle estimate off by 15.9 percentage points, on the low side; measured number inside the range.
By their numbers in this assay, from the lowest: compound 1; then compound 3; then compound 2.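

In this assay, replacing one methoxy group with hydrogen gives a number 15.9 percentage points higher from compound 1 to compound 3 (beyond the scatter), the first single structural change tied to a shift in this read-out. This shows that the methoxy group on this aromatic carbon, ortho to a large group and ortho to another methoxy group, is not needed for the inhibition seen at the one concentration tested, and that the compound without it reads higher. No accompanying measurement explains the shift.

The compounds shown leave open whether the higher number reflects the loss of this methoxy group as such or whether other small replacements on the same carbon, such as a fluorine atom, a chlorine atom or an amine, would shift the read-out in the same direction. They also leave open what removing either of the two remaining methoxy groups would do on its own, and so whether this position is special or any single methoxy group on the shared core could go with a similar result.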